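A few compounds are considered here, and "the series" means these few. Any claim that something is new, unique, unknown or untested is made for them only; others in the source may bear on it.

Measured so far:
compound 1 `COc1ccc(-c2cccc(S(=O)(=O)N3CCC(N4CCC(C)CC4)CC3)c2)cc1` gives > 5000 nM
compound 2 `C#CCCC(=O)CC1CCN(C2CCN(S(=O)(=O)c3c(C)cc(C)cc3C)CC2)CC1` gives > 5000 nM

Both numbers come from an ADME assay on HCT-116 cells (Homo sapiens) for cytotoxicity, read by CellTiter-Glo, with a stated time of 72 h; on this read-out lower numbers stand for stronger inhibition and higher numbers for weaker inhibition. For compound 1 the reading > 5000 nM is a limit of the assay and not a number. For compound 2 the reading > 5000 nM is likewise a limit. Compound 1 therefore stands at the edge of what this assay can report, and it is not alone there (the limit of > 5000 nM in this assay, at which 2 of the 2 values shown sit). For the measured compounds named here, no pair of measured compounds that differ in a single place is available, so no measured step can be drawn on.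

Compound 3 `CC1CCN(C2CCN(S(=O)(=O)c3cccc(Br)c3)CC2)CC1` differs from compound 1 in one place: bromo in place of 4-methoxyphenyl on an aromatic carbon. With both measured compounds sitting at the limit, the starting point for compound 3 is a value that was never resolved into a number, and the change swaps a larger group for a single atom on the same aromatic carbon. The expectation is that this does not move compound 3 beyond the scatter in this assay, so the estimated step is a step that the limit leaves unreadable from compound 1 to compound 3. For compound 3 the estimated value in this assay is 8000 nM, expected to lie between 3000 nM and 30000 nM.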

Compound 3, half-maximal inhibitory concentration: > 5000 nM
Compound 3 ended at the assay's limit (the forecaster's own chance of this, stated with the estimate: 85%); the middle value is on the limit's open side.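

Compound 1 and compound 3 both give a limit of the assay and not a number, so the change from 4-methoxyphenyl to bromo cannot be read as a step of any size: the limit of > 5000 nM in this assay, at which 3 of the 3 values shown sit. The compounds shown leave open what number any of them would reach in this assay, and whether either group makes a difference there.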